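This account rests on a few compounds, and the source may have more. Where it says the series, first, only, none or still open, it means among the compounds named here.

Compound 1 `CCc1nnc(SCC(=O)c2ccc(Cl)cc2)n1N1C(=O)c2ccccc2C1=O`: in a functional assay on A549 cells (Homo sapiens) for cytotoxicity, read by MTT assay, with a stated time of 48 h (a higher number here means a weaker inhibitor, a lower number a stronger inhibitor), compound 1 gives > 200000 nM, a limit of the assay.
Compound 2 `CCc1nnc(SCC(=O)c2ccc(C)cc2)n1N1C(=O)c2ccccc2C1=O`: in this assay compound 2 gives > 200000 nM, a limit of the assay.
Compound 3 `CCCc1nnc(SCC(=O)c2ccc(Cl)cc2)n1N1C(=O)c2ccccc2C1=O`: in this assay compound 3 gives > 200000 nM, a limit of the assay.

From compound 1 to compound 2 the change is methyl in place of chloro on an aromatic carbon; the step it made, a step that the two limits leave unreadable from compound 1 to compound 2, cannot be sized, because of the limit of > 200000 nM in this assay, at which 3 of the 3 values shown sit. The cores of compound 1 and compound 3 differ by methyl in place of hydrogen on a saturated chain carbon, two bonds along the chain from an aromatic carbon, and the step that the two limits leave unreadable from compound 1 to compound 3 is equally unreadable.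

Compound 4 `CCCc1nnc(SCC(=O)c2ccc(C)cc2)n1N1C(=O)c2ccccc2C1=O` is not yet measured. It differs from compound 3 by methyl in place of chloro on an aromatic carbon, the same change as from compound 1 to compound 2, at the same place. Going by the values given here, since compound 3 gives only a limit, > 200000 nM, and compound 2 likewise gives only a limit, the expected step that the limit leaves unreadable from compound 3 to compound 4 rests on no sized step. Compound 4 is estimated at 300000 nM, most likely again reported as a limit.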

Compound 4, half-maximal inhibitory concentration: > 200000 nM
Compound 4 gave a limit, no number; the forecaster's own chance of this, stated with the estimate: 85%; the middle value does not contradict the limit.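

No step from compound 2 or compound 3 to compound 4 can be read, because every value is a limit, not a number: the limit of > 200000 nM in this assay, at which 4 of the 4 values shown sit.

The compounds shown leave open how large either change is in this assay, and whether any member of this series reaches a measurable value.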